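The source may report more compounds than this note shows. Statements on the series, on what has been measured and on what is new or still open speak of the compounds shown alone.

Series notes, measured so far in a physicochemical assay for solubility, in phosphate buffer, with a stated time of 24 h, at pH 7.4, tested at 100 uM; a higher number here means a more soluble compound, a lower number a less soluble compound:

- compound 1 `O=C(NCc1ccc(S(=O)(=O)C2CCOCC2)cc1)N1Cc2ccncc2C1`: 206000 nM
- compound 2 `O=C(NCc1ccc(S(=O)(=O)N2CCC(O)CC2)cc1)N1Cc2ccncc2C1`: 174000 nM

Only these two compounds have been measured, and compound 2 at 174000 nM stands level with compound 1 within the scatter. The next compound is compound 3 `CN1CCN(S(=O)(=O)c2ccc(CNC(=O)N3Cc4ccncc4C3)cc2)CC1`, which keeps the core of compound 2 and changes only the group on the sulfonyl sulfur: 4-methylpiperazin-1-yl in place of 4-hydroxypiperidin-1-yl on a sulfonyl sulfur. In words, this is 4-methylpiperazin-1-yl in place of 4-hydroxypiperidin-1-yl on a sulfonyl sulfur.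

Among the measured compounds shown here, one measured step bears on this change: a 1.2-fold lower number from compound 1 to compound 2 (0.07 log units; within the scatter). It was also a swap of the group at that sulfur, with 4-hydroxypiperidin-1-yl in place of oxan-4-yl, and it stayed within the scatter. For the measured compounds named here, no measured compound carries 4-methylpiperazin-1-yl, so this single step is thin support. On that basis, no step beyond the scatter is expected in this assay, and no direction is favoured. The expected step is a 1.0-fold higher number from compound 2 to compound 3 (0.01 log units; within the scatter). For compound 3 the estimated value is 180000 nM, with an expected range from 90000 nM to 320000 nM.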

Compound 3, solubility: 160000 nM
Compound 3: middle estimate off by 1.1-fold (0.05 log units), on the high side; measured number inside the range.
By their numbers in this assay, from the lowest: compounds 3, 2 and 1 (each within the scatter of the next).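

In this assay, 4-methylpiperazin-1-yl on the sulfonyl sulfur gives a 1.1-fold lower number from compound 2 to compound 3 (0.04 log units; within the scatter) and, set against oxan-4-yl, gives a 1.3-fold lower number from compound 1 to compound 3 (0.11 log units; within the scatter) at the same place. Among the compounds shown here, the series now holds three six-membered non-aromatic rings on this sulfur, all level within the scatter, and for the first time the swap takes the group's hydrogen-bond donors from 1 to 0 with no step beyond the scatter. No supporting measurement bears on why these groups stand level, so the notes record only the numbers and offer no account of them.

Open at this place are groups of a different kind, such as a carboxylic acid, an open-chain amine or a longer alkyl chain in place of the ring, any of which might or might not step beyond the scatter. As far as these compounds go, all three compounds also keep the shared core unchanged, so the effect of any change away from the sulfonyl sulfur on the number in this assay stays unknown.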